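A few compounds are considered here, and "the series" means these few. Any claim that something is new, unique, unknown or untested is made for them only; others in the source may bear on it.

In an ADME assay on HepG2 cells (Homo sapiens) for cytotoxicity, read by resazurin assay, with a stated time of 24 h (on this read-out lower numbers stand for stronger inhibition and higher numbers for weaker inhibition), three compounds sharing one core have been tested so far. Compound 1 (`COc1cc2[nH]c(C)c(-c3ccc(Oc4cccc(OC(F)(F)F)c4)cc3)c(=O)c2cc1Cl`) gives > 10000 nM and this is a limit of the assay. Compound 2 (`COc1cc2[nH]c(C)c(-c3ccc(Oc4ccc(Cl)cc4)cc3)c(=O)c2cc1Cl`) gives > 10000 nM and this too is a limit. Compound 3 (`COc1cc2[nH]c(C)c(-c3ccc(Oc4ccc(OC(F)(F)F)cc4)nc3)c(=O)c2cc1Cl`) gives > 10000 nM and this is again a limit. Compound 3 therefore stands with the other two, as the limit of > 10000 nM in this assay, at which 3 of the 3 values shown sit, shows, and no exact value is known for any of them.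

Compound 4 (`Cc1[nH]c2ccc(Cl)cc2c(=O)c1-c1ccc(Oc2ccc(OC(F)(F)F)cc2)nc1`) has hydrogen in place of methoxy on an aromatic carbon, ortho to a chloro group (hydrogen in place of methoxy on an aromatic carbon). Within the data shown here, the only measured step is a step that the two limits leave unreadable from compound 1 to compound 2 and it changes a different part of the molecule, so no measured step bears directly on this change. No shift beyond the usual scatter is therefore expected, and compound 4 will probably also reach the limit. The expected result is a step that the limit leaves unreadable from compound 3 to compound 4 as an estimate only. For compound 4 the estimated value is 14000 nM with an expected range from 5000 nM to 40000 nM in this assay.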

Compound 4, half-maximal inhibitory concentration: > 10000 nM
Compound 4: a limit, no number; the forecaster's own chance of this, stated with the estimate: 80%; the middle value lies beyond the limit too.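

No size can be read for the change from compound 3 to compound 4 in this assay, because both results are limits: the limit of > 10000 nM in this assay, at which 4 of the 4 values shown sit.

The compounds shown leave open how far beyond that limit each one lies, and whether hydrogen in place of methoxy changes the read-out at all.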